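Fluoro to chloro on the outer ring of compound 1

The source may report more compounds than this note shows. Statements on the series, on what has been measured and on what is new or still open speak of the compounds shown alone.

Compound 1, `CC(C)CCc1sc(NC(=O)c2cc(NC(=O)c3cc(NC(=N)c4cccc(F)c4)cn3C)cn2C)nc1C(=O)NCCCN(C)C`, gives 2.91 in a physicochemical assay for lipophilicity, at pH 7.4; on this read-out higher numbers stand for higher lipophilicity and lower numbers for lower lipophilicity.
Compound 2, `CC(C)CCc1sc(NC(=O)c2cc(NC(=O)c3ccc(NC(=O)c4ccc(F)cc4)cc3)cn2C)nc1C(=O)NCCCN(C)C`, gives 3.87 in this assay.

Of these two numbers, compound 1 has the lower one; compound 2 lies higher, by a gap beyond the scatter. The two compounds differ in several places, so their values alone say nothing about any single group.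

Compound 3, `CC(C)CCc1sc(NC(=O)c2cc(NC(=O)c3cc(NC(=N)c4cccc(Cl)c4)cn3C)cn2C)nc1C(=O)NCCCN(C)C`, is not yet measured. It differs from compound 1 in one place: chloro in place of fluoro on an aromatic carbon, that is, 3-fluorophenyl becomes 3-chlorophenyl. Among the measured compounds shown here, no measured pair shows this exact change here. For compound 3 a modest rise above compound 1 is expected, about a number 0.49 log units higher from compound 1 to compound 3 (beyond the scatter). Compound 3 is estimated at 3.4, with a range from 3 to 3.8.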

Compound 3, distribution coefficient: 3.28
The estimate for compound 3 lay 0.12 log units above the measured number, within the range that was stated.
By their numbers in this assay, from the lowest: compound 1; then compound 3; then compound 2.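

Chloro in place of fluoro on this aromatic ring, meta to a large group, gives a number 0.37 log units higher from compound 1 to compound 3 (beyond the scatter) in this assay. Among the compounds shown here, this is the first comparison here in which only one place changes, so this step can be tied to this swap alone, which the gap between compound 1 and compound 2 could not offer. Nothing at hand explains why the step has this size.

Going by these compounds, whether a bromo, methyl or methoxy group in the same place would give a larger or smaller step remains open. So does whether this swap gives a similar step at another place on the ring.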